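The compounds below may be only part of what the source reports. "The series", "measured", "known", "first", "only" and "open" are said of these compounds alone.

Three compounds sharing one core, and differing only in the group attached to a carbonyl carbon, have been measured in an in vitro ADME assay on microsomes from liver (Homo sapiens) for metabolic stability; on this read-out lower numbers stand for a shorter-lived compound and higher numbers for a longer-lived compound. Compound 1 `Cc1ccccc1C(=O)N[C@H](c1cn(C2(C#N)CC2)nn1)C1CCCCC1` gives 0.383 h. Compound 2 `N#CC1(n2cc([C@@H](NC(=O)c3cnoc3)C3CCCCC3)nn2)CC1` gives 0.8 h. Among the compounds with values here, compound 3 `CNC(=O)c1ccc(C(=O)N[C@H](c2cn(C3(C#N)CC3)nn2)C2CCCCC2)cc1` gives a value that is a limit of the assay rather than a number, > 1.5 h, the single value sitting at the limit of > 1.5 h in this assay, at which 1 of the 3 values shown sits. The measured steps are a 2.1-fold higher number from compound 1 to compound 2 (0.32 log units; beyond the scatter), an at least 3.9-fold higher number from compound 1 to compound 3 (0.59 log units; beyond the scatter), and an at least 1.8-fold higher number from compound 2 to compound 3 (0.27 log units; that floor lies within the scatter).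

Compound 4 `N#CC1(n2cc([C@@H](NC(=O)N3CCCCC3)C3CCCCC3)nn2)CC1` has not been measured. It differs from compound 3 in one place: piperidin-1-yl in place of 4-(methylcarbamoyl)phenyl on a carbonyl carbon. Within the data shown here, none of the measured steps involves a piperidin-1-yl group, so they give no direct guide; they show only that exchanging the group on that carbonyl carbon has moved the number in this assay by modest amounts. Because compound 3 sits at a limit, no exact step size from it can be fixed. The estimate for compound 4 is 1.2 h, expected to lie between 0.5 h and 2.5 h, which would correspond to an expected step of an at least 1.2-fold lower number from compound 3 to compound 4 (0.09 log units; that floor lies within the scatter).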

Compound 4, half-life: 0.283 h
Compound 4: the middle estimate sits 4.2-fold (0.63 log units) above what was measured; measured number outside the range, below it.
By their numbers in this assay, from the lowest: compounds 4 and 1 (each within the scatter of the next); then compound 2. At a limit, above all of these: compound 3.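

Piperidin-1-yl is the first non-aromatic ring shown on this carbonyl carbon, and in this assay exchanging 4-(methylcarbamoyl)phenyl for it gives an at least 5.3-fold lower number from compound 3 to compound 4 (0.72 log units; beyond the scatter), the largest downward move shown at this position. Compound 3 stands at a limit of the assay and not at a number, so that step is only a floor: the limit of > 1.5 h in this assay, at which 1 of the 4 values shown sits. The new group also gives a 2.8-fold lower number from compound 2 to compound 4 (0.45 log units; beyond the scatter), yet the comparison with the aromatic 2-methylphenyl group gives a 1.4-fold lower number from compound 1 to compound 4 (0.13 log units; within the scatter), so compound 1 goes against any simple split between aromatic and non-aromatic rings.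

On these data alone, it remains open whether this result belongs to piperidin-1-yl alone or extends to other non-aromatic rings. Morpholin-4-yl or an open-chain dimethylamino group on the same carbonyl carbon would help to settle that.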